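Glycoside series: extending the exocyclic aryl group in compound 4

The source may report more compounds than this note shows. Statements on the series, on what has been measured and on what is new or still open speak of the compounds shown alone.

Measured so far in a functional assay on HeLa cells (Homo sapiens) for cytotoxicity, read by sulforhodamine B assay, with a stated time of 48 h; on this read-out lower numbers stand for stronger inhibition and higher numbers for weaker inhibition:
compound 1, `COc1ccc2c(c1)c(C=O)cn2Cc1cn([C@@H]2O[C@H](COC(C)=O)[C@@H](OC(C)=O)[C@H](OC(C)=O)[C@H]2OC(C)=O)nn1`: > 200000 nM, a limit of the assay
compound 2, `CC(=O)OC[C@H]1O[C@@H](n2cc(CN3C(=O)/C(=C/c4ccc(C)cc4)c4ccccc43)nn2)[C@H](OC(C)=O)[C@@H](OC(C)=O)[C@@H]1OC(C)=O`: 85600 nM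
compound 3, `CC(=O)OC[C@H]1O[C@@H](n2cc(CN3C(=O)/C(=C\c4ccc(C)cc4)c4ccccc43)nn2)[C@H](OC(C)=O)[C@@H](OC(C)=O)[C@@H]1OC(C)=O`: > 100000 nM, a limit of the assay

Compound 3 therefore stands at a limit, (the limit of > 100000 nM in this assay, at which 1 of the 3 values shown sits), not at a number. Among the compounds with values here, the only one-place step, an at least 1.1-fold higher number from compound 2 to compound 3 (0.06 log units; that floor lies within the scatter), rests on the fact that compounds 2 and 3 differ only in the configuration as drawn and concerns the drawn configuration, not the group exchanged here. Compound 4, `CC(=O)OC[C@H]1O[C@@H](n2cc(CN3C(=O)/C(=C\C=C\c4ccccc4)c4ccccc43)nn2)[C@H](OC(C)=O)[C@@H](OC(C)=O)[C@@H]1OC(C)=O`, differs from compound 3 by 2-phenylethenyl in place of 4-methylphenyl on a double-bonded chain carbon bound to a double-bonded ring carbon. Within the data shown here, no measured step bears on this exchange, so the expectation rests on where compound 3 stands. Compound 4 is expected near 150000 nM, within 50000 nM to 500000 nM. That estimate means a step that the limit leaves unreadable from compound 3 to compound 4, none beyond the scatter, and a limit is again the likelier outcome.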

Compound 4, half-maximal inhibitory concentration: 98100 nM
Beside the measured number, compound 4's estimate is 1.5-fold (0.18 log units) above it; low and high end bracket the measured number.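

With 2-phenylethenyl in place of 4-methylphenyl on a double-bonded chain carbon bound to a double-bonded ring carbon, compound 4 gives a number rather than a limit in this assay. Compound 3 remains a limit of the assay, so any comparison with it has only a floor: the limit of > 100000 nM in this assay, at which 1 of the 4 values shown sits. The exchange reads as an at least 1.0-fold lower number from compound 3 to compound 4 (0.00 log units; that floor lies within the scatter), so no gain in potency can be claimed from it.

As far as these compounds go, how large the true gap is stays open. Also open, from the compounds shown here alone, is whether an amine or a carboxylic acid at this place would shift the number in this assay.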